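The source may hold more compounds than are shown below. What is called first, only, known or untested is meant among the compounds shown, and "the series" means these compounds.

Measured so far in a functional assay on HT-29 cells (Homo sapiens) for antiproliferative activity; a higher number here means a weaker inhibitor, a lower number a stronger inhibitor:
Compound 1 `COc1ccc(Nc2cccc3c2N(S(=O)(=O)c2ccc(OC)cc2)CC3)cc1`: 803 nM
Compound 2 `COc1ccc(S(=O)(=O)N2CCc3cccc(Nc4ccc(F)c(F)c4)c32)cc1`: 968 nM

For the measured compounds named here, compound 2, at 968 nM, cannot be separated from the only other measured compound. Going by the values given here, the single measured step is a 1.2-fold higher number from compound 1 to compound 2 (0.08 log units; within the scatter), and it involves 3,4-difluorophenyl in place of 4-methoxyphenyl on a nitrogen on an aromatic ring.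

The next compound is compound 3 `COc1ccc(S(=O)(=O)N2CCc3cccc(Nc4ccc(C(=O)O)cc4)c32)cc1`, with 4-carboxyphenyl in place of 3,4-difluorophenyl at that same place: 4-carboxyphenyl in place of 3,4-difluorophenyl on a nitrogen on an aromatic ring.

Among the compounds with values here, the one measured step bears on this change only in part. It shows that one exchange at this place left this assay within the scatter, but neither measured compound carries a carboxy group, so the data do not cover the entering group. The flat result for that earlier exchange is therefore not carried over in full. A move towards a weaker inhibitor is expected, with a wide margin that includes no change at all. The estimated step is a 2.6-fold higher number from compound 2 to compound 3 (0.41 log units; beyond the scatter). Compound 3 is estimated at 2500 nM, with an expected range of 700 nM to 12000 nM.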

Compound 3, half-maximal inhibitory concentration: 2380 nM
Compound 3: middle estimate off by 1.1-fold (0.02 log units), on the high side; the range from low to high includes it.
By their numbers in this assay, from the lowest: compounds 1 and 2 (each within the scatter of the next); then compound 3.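

In this assay, for the compounds shown here, this place, on a nitrogen on an aromatic ring, no longer reads as flat: 4-carboxyphenyl in place of 3,4-difluorophenyl gives a 2.5-fold higher number from compound 2 to compound 3 (0.39 log units; beyond the scatter) and is the first exchange here to leave the scatter. Carboxy in place of methoxy on an aromatic carbon points the same way, with a 3.0-fold higher number from compound 1 to compound 3 (0.47 log units; beyond the scatter) as its step, so compound 3 is the weakest inhibitor of the three, while compound 1 and compound 2 remain inseparable. The place therefore accepts the exchange between those two aryl groups without a readable change, but the entering carboxy group moves the number, although only modestly, and nothing at hand bears on why.

Still open, as far as these compounds go, is whether this step belongs to the carboxylic acid as such; a methyl ester or a primary amide at the same place would test that directly. Also open, from the compounds shown here alone, is whether an amine or a hydroxy group on that phenyl ring would follow compound 3 or stay with compound 1 and compound 2.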